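Methoxy-to-hydrogen step and cell viability in three analogues

The compounds below may be only part of what the source reports. "The series", "measured", "known", "first", "only" and "open" are said of these compounds alone.

Three compounds of this series have been run in an ADME assay on RAW264.7 cells (Mus musculus) for cytotoxicity, read by MTT assay, with a stated time of 24 h, tested at 1.25 ug/mL; on this read-out higher numbers stand for a weaker effect at the one concentration tested and lower numbers for a stronger effect. Compound 1 `COc1ccc(C(=O)CCc2cccc(OC)c2OC)c(O)c1` gives 96.6%, compound 2 `COc1ccc(CCCc2ccc(OC)c(OC)c2OC)c(O)c1` gives 96.3% and compound 3 `COc1ccc(C(=O)CCc2ccc(OC)c(OC)c2OC)c(O)c1` gives 101%; all three lie within the usual scatter of one another, so no order among them is drawn. Compound 3 and compound 1 differ in one place only, (hydrogen in place of methoxy on an aromatic carbon), and on this read-out that change made a step of a number 4.4 percentage points lower from compound 3 to compound 1 (within the scatter). Compound 2 and compound 3 differ in more than one place; the difference between the two cores is not broken down here.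

Compound 4 `COc1ccc(CCCc2cccc(OC)c2OC)c(O)c1` has not yet been measured in this assay. Within the data shown here, it differs from compound 2 by hydrogen in place of methoxy on an aromatic carbon, the same change in the same surroundings as the one seen between compound 3 and compound 1. The expected step is a number 2.3 percentage points lower from compound 2 to compound 4 (within the scatter) because a number 4.4 percentage points lower from compound 3 to compound 1 (within the scatter) stayed within the scatter, and a single measured occurrence gives no reason to expect more. Compound 4 is therefore expected to give about 94% in this assay, with a likely range from 85% to 103%.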

Compound 4, a percentage reported as activity, at one concentration (the size of the read-out at that concentration, not a potency): 99.1%
The estimate for compound 4 lay 5.1 percentage points below the measured number, and the stated range covers the measured number.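

In this assay, hydrogen in place of methoxy on an aromatic carbon gives a number 2.8 percentage points higher from compound 2 to compound 4 (within the scatter). Set beside the earlier occurrence of this change on the other core, the new step shows no difference between the two cores: the same change on two cores in this assay, a number 4.4 percentage points lower (within the scatter) from compound 3 to compound 1 and a number 2.8 percentage points higher (within the scatter) from compound 2 to compound 4, 7.2 percentage points apart, within the scatter of two such steps. This supports only a modest statement, that on these two cores the change left the read-out within the scatter at the one concentration tested; it establishes no direction or size for the step, and it does not show that the same would hold on a third core or at other concentrations.

As far as these compounds go, all four compounds carry only methoxy or hydrogen at this aromatic carbon, so it remains open whether an amine, a carboxylic acid or a longer alkoxy chain there would also stay within the scatter. Also open, from the compounds shown here alone, is whether the same change would behave alike with a longer chain joining the two aromatic rings.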